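This account rests on a few compounds, and the source may have more. Where it says the series, first, only, none or still open, it means among the compounds named here.

Values as measured in a functional assay on HOS cells (Homo sapiens) for antiproliferative activity, read by sulforhodamine B assay; on this read-out higher numbers stand for weaker inhibition of growth and lower numbers for stronger inhibition of growth:
Compound 1 (`C=CC[C@@H]1O[C@H](COCc2ccccc2)[C@@H](OCc2ccccc2)[C@H](OCc2ccccc2)[C@H]1O`): 44100 nM
Compound 2 (`O[C@@H]1[C@@H](OCc2ccccc2)[C@H](OCc2ccccc2)[C@@H](COCc2ccccc2)O[C@H]1c1ccccc1`): > 50000 nM

Compound 2 stands only at a limit of the assay, not at a number (the limit of > 50000 nM in this assay, at which 1 of the 2 values shown sits). Compound 3 (`O[C@@H]1[C@@H](OCc2ccccc2)[C@H](OCc2ccccc2)[C@@H](COCc2ccccc2)O[C@H]1Cc1ccccc1`) has benzyl in place of phenyl on a saturated ring carbon, next to the ring oxygen (benzyl in place of phenyl on a saturated ring carbon). Among the compounds with values here, the one measured step at this place, an at least 1.1-fold higher number from compound 1 to compound 2 (0.05 log units; that floor lies within the scatter) for phenyl in place of allyl, is only a floor. It gives no firm size or direction to carry over. No step beyond the scatter is therefore expected in this assay, and compound 3 may well also return only a limit. If a number is returned, it is expected to be modest growth inhibition. The estimated step is an at least 1.3-fold lower number from compound 2 to compound 3 (0.11 log units; that floor lies within the scatter) in this reading. For compound 3 the expected value is 38000 nM (estimated range 15000 nM to 50000 nM).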

Compound 3, concentration for 50% growth inhibition: 29200 nM
For compound 3 the middle estimate is 1.3-fold (0.11 log units) above the measured one; low and high end bracket the measured number.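

From the compounds shown here alone, compound 2 is held at a limit of this assay, not at a number: the limit of > 50000 nM in this assay, at which 1 of the 3 values shown sits. With benzyl on the saturated ring carbon next to the ring oxygen, this assay gives a number, and the change from phenyl reads as an at least 1.7-fold lower number from compound 2 to compound 3 (0.23 log units; that floor lies within the scatter); this is only a floor, so the true size of the step remains unknown. The comparison of allyl with benzyl at this position gives a 1.5-fold lower number from compound 1 to compound 3 (0.18 log units; within the scatter), so these two groups cannot be told apart in this assay.

Going by these compounds, whether phenyl and benzyl truly differ at this position stays open. Also open, on these data alone, is whether an amine, a carboxylic acid or a longer chain here would shift growth inhibition beyond the scatter.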